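This account rests on a few compounds, and the source may have more. Where it says the series, first, only, none or still open, it means among the compounds named here.

Measured compounds:
Compound 1 `CCCC[C@H](NC(=O)[C@H](CCCCN)NC(=O)[C@H](CCCNC(=N)N)NC(=O)c1ccc(/C=C2\SC(=S)N(c3ccc(Cl)cc3)C2=O)cc1)C(N)=O` gives 1.02 10^-6 cm/s in an ADME assay for permeability, using PAMPA; a higher number here means that the compound crosses the layer faster, a lower number that the compound crosses the layer more slowly.
Compound 2 `CCCC[C@H](NC(=O)[C@H](CCCCN)NC(=O)[C@H](CCCNC(=N)N)NC(=O)c1ccc(/C=C2\SC(=S)N(CCCC)C2=O)cc1)C(N)=O` gives 1.61 10^-6 cm/s in this assay.
Compound 3 `CCCC[C@H](NC(=O)[C@H](CCCCN)NC(=O)[C@H](CCCNC(=N)N)NC(=O)c1ccc(/C=C2\SC(=S)N(Cc3ccc(OC)cc3)C2=O)cc1)C(N)=O` gives 0.6 10^-6 cm/s in this assay.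

Compound 3 holds the lowest of the three numbers. Its nearest neighbour is compound 1, with a 1.7-fold lower number from compound 1 to compound 3 (0.23 log units; within the scatter), and its furthest is compound 2, with a 2.7-fold lower number from compound 2 to compound 3 (0.43 log units; beyond the scatter). The unmeasured compound 4 `CCCCC(C(=O)OC)N1C(=O)/C(=C/c2ccc(C(=O)N[C@@H](CCCNC(=N)N)C(=O)N[C@@H](CCCCN)C(=O)N[C@@H](CCCC)C(N)=O)cc2)SC1=S` differs from compound 3 in one place: 1-(methoxycarbonyl)pentyl in place of 4-methoxybenzyl on an amide-type nitrogen in a ring. Going by the values given here, three measured steps touch the same ring nitrogen. The exchange a 1.6-fold higher number from compound 1 to compound 2 (0.20 log units; within the scatter) stayed within the scatter, as did a 1.7-fold lower number from compound 1 to compound 3 (0.23 log units; within the scatter), while a 2.7-fold lower number from compound 2 to compound 3 (0.43 log units; beyond the scatter) was a modest step beyond it. The entering group in compound 4 is a chain rather than an aryl or benzyl group, which most resembles the butyl of compound 2. Compound 4 is therefore expected to sit somewhat above compound 3 in this assay, with the step of a 2.0-fold higher number from compound 3 to compound 4 (0.30 log units; within the scatter) estimated to be about the size of the step to compound 2. The estimate for compound 4 is 1.2 10^-6 cm/s, expected to fall between 0.6 10^-6 cm/s and 2.4 10^-6 cm/s.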

Compound 4, apparent permeability: 0.87 10^-6 cm/s
Estimate against measurement, compound 4: 1.4-fold (0.14 log units) above; the range from low to high includes it.
By their numbers in this assay, from the lowest: compounds 3, 4, 1 and 2 (each within the scatter of the next, the first and the last beyond it).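

On the amide-type nitrogen in a ring, 1-(methoxycarbonyl)pentyl, a group with no ring, stays within the scatter of all three earlier groups in this assay (a 1.5-fold higher number from compound 3 to compound 4 (0.16 log units; within the scatter); a 1.9-fold lower number from compound 2 to compound 4 (0.27 log units; within the scatter); a 1.2-fold lower number from compound 1 to compound 4 (0.07 log units; within the scatter)). Going by these compounds alone, until now butyl was the only ringless group at this position, and compound 4 shows that a chain carrying methoxycarbonyl can stand there without a step beyond the scatter from any earlier compound, including compound 2 and compound 3, the one pair that lies beyond it. Nothing measured here speaks to why these groups give such numbers. It remains open whether a carboxylic acid in place of the methoxycarbonyl, an amine on the pentyl chain, or a longer chain would also stay within the scatter of these compounds.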